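Swapping a Fluorophenyl for a Pyridine in a Cytotoxicity Series

The compounds below may be only part of what the source reports. "The series", "measured", "known", "first", "only" and "open" are said of these compounds alone.

Compound 2 `Fc1ccccc1Cn1ccc2nc(-c3ccccc3)nc-2c1` was tested in an ADME assay on MDBK cells (Bos taurus) for cytotoxicity (on this read-out higher numbers stand for lower toxicity in this test and lower numbers for higher toxicity in this test), and its result is only a limit, > 100000 nM. Compound 1 `Fc1cccc(F)c1-c1nc2ccn(Cc3ccccc3)cc-2n1` likewise reaches only a limit in this assay, > 100000 nM. Compound 3 `FC(F)(F)c1ccc(Cn2ccc3nc(-c4ccccc4)nc-3c2)cc1` gives 84000 nM in this assay. Compound 2 thus stands at the limit of > 100000 nM in this assay, at which 2 of the 3 values shown sit. Compound 4 `c1ccc(-c2nc3ccn(Cc4cccnc4)cc-3n2)cc1` has not yet been measured; it differs from compound 2 by pyridin-3-yl in place of 2-fluorophenyl on a saturated chain carbon bound to an aromatic nitrogen. Within the data shown here, with no comparable step among the measured compounds, the expectation for this assay is a change no larger than the usual scatter, in no firm direction. Compound 4 is therefore expected to give 100000 nM, within 40000 nM to 250000 nM, quite possibly again only a limit. The expected step of a number no higher from compound 2 to compound 4 (the limit leaves the size open) is accordingly close to nil.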

Compound 4, half-maximal cytotoxic concentration: > 100000 nM
Compound 4 ended at the assay's limit; the forecaster's own chance of this, stated with the estimate: 60%; the middle value lies on the limit itself.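

Among these compounds, compound 2 and compound 4 both end at a limit of this assay rather than at a number, so no step between them can be read. The compounds shown leave open whether pyridin-3-yl in place of 2-fluorophenyl changes toxicity at all.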